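The source may hold more compounds than are shown below. What is called first, only, known or untested is meant among the compounds shown, and "the series" means these compounds.

Series notes. Compound 1 `CC(C)N1CCN(Cc2csc(N)c2C(=O)c2ccc(Cl)cc2)CC1` and compound 2 `COc1ccc(N2CCN(Cc3csc(N)c3C(=O)c3ccc(Cl)cc3)CC2)cc1` share one core and differ only in the group on the amine nitrogen in a ring. In a functional assay on CHO cells with adenosine receptor A1 (Homo sapiens) as the target, read by cAMP accumulation and immunoassay, with a stated time of 6 min, tested at 1 uM (a higher number here means a weaker effect of the compound at the concentration tested, a lower number a stronger effect), compound 1 gives 7.3% and compound 2 gives -15%; the step of a number 22.3 percentage points lower from compound 1 to compound 2 (beyond the scatter) leaves compound 2 with the lowest of the two numbers recorded, compound 1 being its nearest neighbour. Compound 3 `Nc1scc(CN2CCN(c3cccnc3)CC2)c1C(=O)c1ccc(Cl)cc1` is not yet measured and differs from compound 2 by pyridin-3-yl in place of 4-methoxyphenyl on an amine nitrogen in a ring. Within the data shown here, the one measured step exchanged an isopropyl for an aryl ring on the same amine nitrogen in a ring and moved the number by a number 22.3 percentage points lower from compound 1 to compound 2 (beyond the scatter); no measured step exchanges one aryl ring for another, so that step bears on compound 3 only indirectly. In this assay the expected step is a number 5 percentage points higher from compound 2 to compound 3 (within the scatter). Compound 3 is estimated at -10%, with a range from -30% to 12%.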

Compound 3, a percentage reported as activity, at one concentration (the size of the read-out at that concentration, not a potency): -2.7%
Estimate against measurement, compound 3: 7.3 percentage points below; the measured number falls inside the stated range.
By their numbers in this assay, from the lowest: compound 2; then compounds 3 and 1 (each within the scatter of the next).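

Among these compounds, this is the first exchange of one aryl ring for another on the amine nitrogen in a ring: in this assay the change gives a number 12.3 percentage points higher from compound 2 to compound 3 (beyond the scatter) and shows that the number depends on which aryl ring sits there, not only on an aryl ring being present. Set against the isopropyl of compound 1, pyridin-3-yl gives a number 10 percentage points lower from compound 1 to compound 3 (within the scatter) and so is not separated from it, which leaves the 4-methoxyphenyl of compound 2 as the only group of the three standing apart from both others. Nothing measured here accounts for that difference.

Pyridin-3-yl differs from 4-methoxyphenyl in both the ring nitrogen and the methoxy group, so the compounds shown do not tell which of the two matters; a plain phenyl on the same nitrogen would separate them. As far as these compounds go, whether a longer methoxy-bearing group such as 4-ethoxyphenyl moves the number further also remains open.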